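Benzoyl ester of the hydroxyethyl side chain: expected cytotoxicity

The compounds below may be only part of what the source reports. "The series", "measured", "known", "first", "only" and "open" are said of these compounds alone.

Compound 1 `O=c1[nH]c2ccc(Cl)cc2c(-c2ccccc2Cl)c1CCO` is the parent of this small series. In an ADME assay on HepG2 2.2.15 cells (Homo sapiens) for cytotoxicity (a lower number here means that less compound is tolerated, a higher number that more compound is tolerated), compound 1 gives 380000 nM, the highest of the three numbers recorded. Its two esters sit lower: compound 2 `CCOCC(=O)OCCc1c(-c2ccccc2Cl)c2cc(Cl)ccc2[nH]c1=O` gives 130000 nM and compound 3 `O=C(OCCc1c(-c2ccccc2Cl)c2cc(Cl)ccc2[nH]c1=O)C1CCCC1` gives 46000 nM. Compound 4 `O=C(OCCc1c(-c2ccccc2Cl)c2cc(Cl)ccc2[nH]c1=O)c1ccccc1` differs from compound 1 by benzoyl in place of hydrogen on an oxygen on a saturated carbon. Among the measured compounds shown here, the steps that bear on this change are a 2.9-fold lower number from compound 1 to compound 2 (0.47 log units; beyond the scatter) and an 8.3-fold lower number from compound 1 to compound 3 (0.92 log units; beyond the scatter), and between the two esters a 2.8-fold lower number from compound 2 to compound 3 (0.45 log units; beyond the scatter). Both acylations lowered the number beyond the scatter, so a further lowering is expected for compound 4, of a size near that seen for compound 3, namely an 8.4-fold lower number from compound 1 to compound 4 (0.93 log units; beyond the scatter). Compound 4 is therefore estimated at 45000 nM, within the range 15000 nM to 140000 nM.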

Compound 4, half-maximal cytotoxic concentration: 43000 nM
Estimate against measurement, compound 4: 1.0-fold (0.02 log units) above; the measured number falls inside the stated range.
By their numbers in this assay, from the lowest: compounds 4 and 3 (each within the scatter of the next); then compound 2; then compound 1.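

In this assay benzoyl on this oxygen gives an 8.8-fold lower number from compound 1 to compound 4 (0.95 log units; beyond the scatter) and so lowers the number much as the cyclopentylcarbonyl group does. Phenyl and cyclopentyl on the carbonyl carbon are not told apart, with a 1.1-fold lower number from compound 3 to compound 4 (0.03 log units; within the scatter) as the step between them, while a 3.0-fold lower number from compound 2 to compound 4 (0.48 log units; beyond the scatter) separates phenyl from ethoxymethyl. Among the three esters, compounds 3 and 4, with a ring on the carbonyl carbon, sit together, and compound 2 stands apart from them.

No available evidence accounts for these differences. From the compounds shown here alone, how an acyl group bearing an amine, a carboxylic acid or a longer chain would behave at this oxygen remains open.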